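The compounds below may be only part of what the source reports. "The series", "measured", "known", "first", "only" and "open" are said of these compounds alone.

Working notes on the benzyloxy acetophenone series

Of the compounds shown here, three have been measured in an assay on isolated protein for inhibition of Amine oxidase [flavin-containing] B (Homo sapiens), read by Amplex Red, with a stated time of 15 min; on this read-out higher numbers stand for weaker inhibition and lower numbers for stronger inhibition. Compound 1 `CC(=O)c1ccc(OCc2ccccc2C)cc1` gives 77.1 nM in this assay. Compound 2 `CC(=O)c1ccc(OCc2ccc(C)cc2)cc1` gives 102 nM, and compound 3 `CC(=O)c1ccc(OCc2cccc([N+](=O)[O-])c2)cc1` gives 104 nM. Compound 1 carries the lowest of the three numbers, yet both compound 2 and compound 3 lie within the scatter of it, so the three measured compounds cannot be told apart on this read-out. Among the measured compounds shown here, no pair of them differs in a single place, so no measured step is available to guide the next change.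

Compound 4 `CC(=O)c1ccc(OCc2ccccc2F)cc1` is the next compound to be measured in this assay. It differs from compound 1 by fluoro in place of methyl on an aromatic carbon. With no measured step of this kind in the series, and with all three measured numbers sitting within scatter of one another, the step from compound 1 to compound 4 is expected to be small, in either direction, and most likely not beyond the scatter: a 1.2-fold higher number from compound 1 to compound 4 (0.07 log units; within the scatter). On that basis compound 4 is estimated at 90 nM in this assay, with a range from 40 nM to 200 nM.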

Compound 4, half-maximal inhibitory concentration: 56.9 nM
Compound 4: the middle estimate sits 1.6-fold (0.20 log units) above what was measured, within the range that was stated.
By their numbers in this assay, from the lowest: compounds 4, 1, 2 and 3 (each within the scatter of the next).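

In this assay, fluoro in place of methyl on an aromatic carbon, ortho to a large group, gives a 1.4-fold lower number from compound 1 to compound 4 (0.13 log units; within the scatter) and so leaves the two compounds indistinguishable on this read-out. Among the compounds shown here, this is the first measured step that differs in one place, and it shows that this position takes either group without a readable change, at least for this exchange of one heavy atom with no hydrogen-bond donors, acceptors or net charge on either side. No measured property bears on this step, and nothing can be said of what lies behind it.

Still open, on these data alone, is whether a different group at this position, such as methoxy, trifluoromethyl or an amine, would move the number beyond the scatter. Also open, as far as these compounds go, is whether fluoro in place of the methyl of compound 2 would give a step of like size.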